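Naphthalen-2-yl Replaces Thiophen-2-yl on the Sulfonyl Sulfur

This account rests on a few compounds, and the source may have more. Where it says the series, first, only, none or still open, it means among the compounds named here.

In a functional assay on SW-620 cells (Homo sapiens) for cytotoxicity, read by MTT assay, with a stated time of 48 h (on this read-out higher numbers stand for weaker inhibition and lower numbers for stronger inhibition), compound 2 `CCCCCCCCCCCCCCNC(=O)[C@@H](NS(=O)(=O)c1cccs1)[C@@H](C)O` gives 18400 nM. Among the measured compounds shown here, its only neighbour in the data is compound 1 `CCCCCCCCCCCCCCNC(=O)[C@@H](NS(=O)(=O)c1ccc(C)cc1)[C@@H](C)O`, which in this assay gives 15200 nM; the two values lie within the scatter of each other, as a 1.2-fold higher number from compound 1 to compound 2 (0.08 log units; within the scatter) shows. Compound 3 `CCCCCCCCCCCCCCNC(=O)[C@@H](NS(=O)(=O)c1ccc2ccccc2c1)[C@@H](C)O` carries naphthalen-2-yl in place of thiophen-2-yl on a sulfonyl sulfur. Only the swap from compound 1 to compound 2 bears on this change, and it produced no step beyond the scatter, so a further swap of the aryl group on the sulfonyl sulfur is expected to leave this assay largely unchanged. Compound 3 is therefore expected to give 14000 nM, with a range from 5000 nM to 40000 nM. The expected step of a 1.3-fold lower number from compound 2 to compound 3 (0.12 log units; within the scatter) is thus estimated to remain within the scatter.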

Compound 3, half-maximal inhibitory concentration: 9360 nM
For compound 3 the middle estimate is 1.5-fold (0.17 log units) above the measured one, within the range that was stated.
By their numbers in this assay, from the lowest: compounds 3, 1 and 2 (each within the scatter of the next).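

In this assay, the two six-membered aromatic rings of naphthalen-2-yl on the sulfonyl sulfur stay within the scatter of both earlier groups, against thiophen-2-yl (a 2.0-fold lower number from compound 2 to compound 3 (0.29 log units; within the scatter)) and against 4-methylphenyl (a 1.6-fold lower number from compound 1 to compound 3 (0.21 log units; within the scatter)). Across these three compounds, then, even this larger aromatic group produces no step beyond the scatter at this position. Going by these compounds, whether a plain methyl group, or an aromatic ring carrying an amine or a carboxylic acid, would do so on the sulfonyl sulfur remains open. Nothing available explains these numbers.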